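Fluorinated phenyl replacement and expected permeability of compound 4

A few compounds are considered here, and "the series" means these few. Any claim that something is new, unique, unknown or untested is made for them only; others in the source may bear on it.

Three compounds in this series carry a measured value in a physicochemical assay for permeability, using PAMPA, with a stated time of 4 h, at pH 7.4, tested at 50 uM; on this read-out higher numbers stand for higher permeability and lower numbers for lower permeability. Compound 1, `Cc1c(Cl)cccc1CCCCOc1ccc(C#Cc2cccc3c(CCCC(=O)O)c(C)n(CCCCC(=O)O)c23)cc1`, gives 5 10^-6 cm/s in this assay. Compound 2, `Cc1c(CCCC(=O)O)c2cccc(/C=C/c3ccc(OCCCCc4cc(F)c(F)c(F)c4F)cc3)c2n1CC(=O)O`, gives 0.3 10^-6 cm/s in this assay. Compound 3, `Cc1c(F)cccc1CCCCOc1ccc(/C=C/c2cccc3c(CCCC(=O)O)cn(CC(=O)O)c23)cc1`, is reported in this assay only as a limit of the assay, < 0.05 10^-6 cm/s, and not as a number. Compound 3 therefore sits at the limit of < 0.05 10^-6 cm/s in this assay, at which 1 of the 3 values shown sits, the bottom of the three results shown, while compound 1 and compound 2 each return a number.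

Compound 4, `O=C(O)CCCc1cn(CC(=O)O)c2c(/C=C/c3ccc(OCCCCc4c(F)ccc(F)c4F)cc3)cccc12`, is not yet measured. It differs from compound 3 by 2,3,6-trifluorophenyl in place of 3-fluoro-2-methylphenyl on a saturated chain carbon, four bonds along the chain from an oxygen on an aromatic ring. Within the data shown here, no measured pair in the set differs in only this place, so the step has no direct precedent here; compound 2 also carries a polyfluorinated phenyl on its chain but differs from compound 3 elsewhere as well, so its value is read only as a rough pointer.

The step from compound 3 to compound 4 is expected to be small, an at least 1.6-fold higher number from compound 3 to compound 4 (0.20 log units; that floor lies within the scatter), with compound 4 staying near the bottom of the measured range and a real chance that it is again reported only as a limit. Compound 4 is estimated at 0.08 10^-6 cm/s in this assay, with a range from 0.03 10^-6 cm/s to 0.3 10^-6 cm/s.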

Compound 4, apparent permeability: < 0.05 10^-6 cm/s
Compound 4: a limit, no number; the forecaster's own chance of this, stated with the estimate: 40%; middle value at least 1.6-fold (0.20 log units) away from the limit.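

Compound 3 and compound 4 each return only a limit of the assay in this assay, so no step between them can be read: the limit of < 0.05 10^-6 cm/s in this assay, at which 2 of the 4 values shown sit.

The compounds shown leave open whether 2,3,6-trifluorophenyl in place of 3-fluoro-2-methylphenyl changes the read-out at all, since neither compound gives a number to compare.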